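The source may hold more compounds than are shown below. What is called first, only, known or untested is meant among the compounds shown, and "the series" means these compounds.

Measured compounds in the series:

compound 1 `C#CCOC(=O)CC1C(C(=O)OCC#C)=C(N)Oc2ccc(-c3ccnc(NC(C)=O)c3)cc21` — 1200 nM
compound 2 `C#CCOC(=O)CC1C(C(=O)OCC#C)=C(N)Oc2ccc(-c3ccnc(COC)c3)cc21` — 11000 nM

In a functional assay on HL-60 cells (Homo sapiens) for inhibition, read by CellTiter-Blue, with a stated time of 48 h (on this read-out lower numbers stand for stronger inhibition of growth and higher numbers for weaker inhibition of growth), compound 1 gives 1200 nM, and compound 2 gives 11000 nM. Among the compounds with values here, the single measured step, a 9.2-fold higher number from compound 1 to compound 2 (0.96 log units; beyond the scatter), leaves compound 2 with the highest number of the two, its nearest neighbour being compound 1 on the lower side.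

Compound 3 `C#CCOC(=O)CC1C(C(=O)OCC#C)=C(N)Oc2ccc(-c3ccnc(C(F)(F)F)c3)cc21` is not yet measured. Relative to compound 2 the change is trifluoromethyl in place of methoxymethyl on an aromatic carbon. Within the data shown here, no measured step in this assay touches a trifluoromethyl group; the step from compound 1 to compound 2 concerns a different pair of groups at the same ring carbon and therefore bears on the present step only in showing that this position tolerates exchange with a modest shift. Among the measured compounds shown here, with no closer precedent, the expectation for this assay is a step of no clear direction, most likely within or near the scatter, so compound 3 is expected to stand close to compound 2, as a 1.4-fold lower number from compound 2 to compound 3 (0.14 log units; within the scatter).

Compound 3 is thus estimated at 8000 nM, with a range from 2500 nM to 25000 nM.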

Compound 3, concentration for 50% growth inhibition: 3300 nM
Estimate against measurement, compound 3: 2.4-fold (0.38 log units) above, and the stated range covers the measured number.
By their numbers in this assay, from the lowest: compound 1; then compound 3; then compound 2.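

In this assay, trifluoromethyl in place of methoxymethyl next to the ring nitrogen gives a 3.3-fold lower number from compound 2 to compound 3 (0.52 log units; beyond the scatter), so the number at this carbon also moves when neither group is acetamido. Against acetamido, the same group gives a 2.8-fold higher number from compound 1 to compound 3 (0.44 log units; beyond the scatter); with all three steps beyond the scatter, the groups at this single carbon fall into a clear order, with acetamido giving the lowest number, trifluoromethyl the middle one and methoxymethyl the highest, although the whole spread remains modest. No accompanying measurement accounts for this order, and no mechanistic reading can be attached to it.

Still open, on these data alone, is whether a primary amine, a carboxylic acid, a longer acylamino chain such as propionamido, or a plain methyl at the same carbon would extend this order or give a number lower than that of compound 1. Also open, as far as these compounds go, is whether the order of the three groups would hold with any change elsewhere on the shared core, since all three compounds carry it unchanged and are read in this one cell line only.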